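Changing the Benzyl Ring in a Thiourea Series

The source may report more compounds than this note shows. Statements on the series, on what has been measured and on what is new or still open speak of the compounds shown alone.

Compound 1, `Cc1ccc(NC(=S)NC(=O)c2ccc(OCc3ccc(C(F)(F)F)cc3)cc2)cc1-c1nc2ccccc2[nH]1`: 6500 nM
Compound 2, `Cc1ccc(NC(=S)NC(=O)c2ccc(OCc3cccc(F)c3)cc2)cc1-c1nc2ccccc2[nH]1`: > 100000 nM, a limit of the assay
Compound 3, `O=C(NC(=S)Nc1ccc(Cl)c(-c2nc3ccccc3[nH]2)c1)c1ccc(OCc2ccc(C(F)(F)F)cc2)cc1`: 5330 nM

In a functional assay on MGC-803 cells (Homo sapiens) for inhibition, read by MTT assay, with a stated time of 48 h (a lower number here means a stronger inhibitor, a higher number a weaker inhibitor), compound 1 gives 6500 nM. Compound 2 gives > 100000 nM, which is a limit of the assay rather than a number. Compound 3 gives 5330 nM; of the two numbers shown, compound 3 and compound 1 sit within the usual scatter of each other, as a 1.2-fold lower number from compound 1 to compound 3 (0.09 log units; within the scatter) shows. Compound 4, `O=C(NC(=S)Nc1ccc(Cl)c(-c2nc3ccccc3[nH]2)c1)c1ccc(OCc2ccc(Cl)cc2Cl)cc1`, is not yet measured and differs from compound 3 by 2,4-dichlorophenyl in place of 4-(trifluoromethyl)phenyl on a saturated chain carbon bound to an oxygen on an aromatic ring. Within the data shown here, the one measured step at this same place is an at least 15-fold higher number from compound 1 to compound 2 (1.18 log units; beyond the scatter); the step of a 1.2-fold lower number from compound 1 to compound 3 (0.09 log units; within the scatter) lies elsewhere and bears little on it. A moderate step, with uncertain direction, is expected, a 1.5-fold higher number from compound 3 to compound 4 (0.18 log units; within the scatter). Compound 4 is estimated at 8000 nM, between 2500 nM and 40000 nM.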

Compound 4, half-maximal inhibitory concentration: 3030 nM
For compound 4 the middle estimate is 2.6-fold (0.42 log units) above the measured one; the range from low to high includes it.
By their numbers in this assay, from the lowest: compounds 4, 3 and 1 (each within the scatter of the next, the first and the last beyond it). At a limit, above all of these: compound 2.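

In this assay, a 1.8-fold lower number from compound 3 to compound 4 (0.25 log units; within the scatter) shows that this place can hold two differently substituted rings with no difference beyond the usual scatter. Among these compounds, the only earlier change here, an at least 15-fold higher number from compound 1 to compound 2 (1.18 log units; beyond the scatter), gave no sign that a replacement could keep the activity of the parent compound. The value of compound 2 is a limit, not a number: the limit of > 100000 nM in this assay, at which 1 of the 4 values shown sits.

Going by these compounds, it remains open whether the 3-fluorophenyl ring of compound 2 would behave the same way alongside the chloro of compound 3. On these data alone, the effect of a methoxy group or an amine on this ring also remains open.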